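Chloro in Place of Methyl: Expected Binding of Compound 3

The compounds below may be only part of what the source reports. "The series", "measured", "known", "first", "only" and "open" are said of these compounds alone.

Measured so far:
compound 1 `Cc1cccc(-c2cnc(N)nc2-c2ccccc2)c1` — 205 nM
compound 2 `Nc1ncc(-c2ccc(F)cc2)c(-c2ccccc2)n1` — 160 nM

In an assay on CHO cells for displacement of a labelled ligand from adenosine receptor A1 (Homo sapiens), read by scintillation counting, with a stated time of 1 h (on this read-out lower numbers stand for stronger inhibition and higher numbers for weaker inhibition), compound 1 gives 205 nM, the higher of the two numbers recorded. Compound 2 gives 160 nM, a gap that lies within the scatter, so the two stand level. Compound 3 `Nc1ncc(-c2cccc(Cl)c2)c(-c2ccccc2)n1` differs from compound 1 by chloro in place of methyl on an aromatic carbon, the site being meta to a large group. Going by the values given here, no step between measured compounds of this kind exists, so the change is expected to stay within the scatter, without a clear direction. Compound 3 is therefore expected to give 180 nM (range 60 nM to 550 nM), which would be a step of a 1.1-fold lower number from compound 1 to compound 3 (0.06 log units; within the scatter).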

Compound 3, inhibition constant: 55 nM
Compound 3: middle estimate off by 3.3-fold (0.51 log units), on the high side; measured number outside the range, below it.
By their numbers in this assay, from the lowest: compound 3; then compounds 2 and 1 (each within the scatter of the next).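

In this assay, chloro in place of methyl on an aromatic carbon, meta to a large group, gives a 3.7-fold lower number from compound 1 to compound 3 (0.57 log units; beyond the scatter) and so shows that the number responds to what sits at this position. This modest step, the only one available, lies beyond the scatter. Nothing measured here accounts for it. The compounds shown leave open how an amine, a methoxy group or a carboxylic acid at this position would read, and whether bromo would extend the step seen with chloro.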